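Swapping an aryl group for a styryl group on a pyrazoline core

The source may report more compounds than this note shows. Statements on the series, on what has been measured and on what is new or still open speak of the compounds shown alone.

Compound 2 `Cc1cc(O)c(C2=NN(c3ccc(S(N)(=O)=O)cc3)C(c3ccccc3Cl)C2)cc1Cl` in a functional assay on PC-3 cells (Homo sapiens) for antiproliferative activity, with a stated time of 48 h (a lower number here means that less compound is tolerated, a higher number that more compound is tolerated), gives 6980 nM.
Compound 1 `Cc1cc(O)c(C2=NN(c3ccc(S(N)(=O)=O)cc3)C(c3ccccc3O)C2)cc1Cl` in this assay gives 9330 nM.

For the measured compounds named here, compound 2 has the lowest of the two numbers so far, but the step of a 1.3-fold lower number from compound 1 to compound 2 (0.13 log units; within the scatter) is within the scatter, so the two compounds cannot be told apart. Compound 3 `Cc1cc(O)c(C2=NN(c3ccc(S(N)(=O)=O)cc3)C(/C=C/c3ccccc3)C2)cc1Cl` brings a different kind of change: 2-phenylethenyl in place of 2-chlorophenyl on a saturated ring carbon. Going by the values given here, no measured step involves such an exchange; the only known step, a chloro for a hydroxy on the aryl ring, was within the scatter and offers little guidance. Compound 3 is therefore expected near compound 2, with a step of a 1.1-fold higher number from compound 2 to compound 3 (0.03 log units; within the scatter), and an estimate of 7500 nM, ranging from 2500 nM to 22000 nM.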

Compound 3, concentration lethal to 50% of the cells: 34000 nM
Compound 3: the middle estimate sits 4.5-fold (0.66 log units) below what was measured; the measured number lies above the stated range.
By their numbers in this assay, from the lowest: compounds 2 and 1 (each within the scatter of the next); then compound 3.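

This saturated ring carbon responds to what it carries. In this assay, replacing 2-chlorophenyl with 2-phenylethenyl gives a step beyond the scatter (a 4.9-fold higher number from compound 2 to compound 3 (0.69 log units; beyond the scatter)), and replacing 2-hydroxyphenyl with it gives another (a 3.6-fold higher number from compound 1 to compound 3 (0.56 log units; beyond the scatter)), whereas the chloro-for-hydroxy change on the aryl ring did not separate compound 1 from compound 2. Nothing available explains this shift.

Still open, going by these compounds, is whether the double bond itself matters, which a saturated 2-phenylethyl chain at this carbon would test. Also open, on these data alone, is how an amine or a carboxylic acid on the new phenyl ring would read.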